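Swapping a benzimidazole for a saturated oxane ring

The compounds below may be only part of what the source reports. "The series", "measured", "known", "first", "only" and "open" are said of these compounds alone.

Compound 1 `CNC(=O)c1cc(C(=O)NC2CC2)cn(Cc2cccc(OC)c2)c1=O` gives 79 ug/mL in a physicochemical assay for solubility; on this read-out higher numbers stand for higher solubility and lower numbers for lower solubility.
Compound 2 `CNC(=O)c1cc(C(=O)NC2CC2)cn(CC2CCCOC2)c1=O` reaches only the limit >= 131 ug/mL in this assay.
Compound 3 `CNC(=O)c1cc(C(=O)NC2CC2)cn(Cc2ccc3nc[nH]c3c2)c1=O` likewise reaches only the limit >= 163 ug/mL in this assay.

Compound 3 therefore stands at a limit of this assay, not at a number; it is the higher of the two limits reported here (the limit of >= 163 ug/mL in this assay, at which 1 of the 3 values shown sits). Its step of an at least 2.0-fold higher number from compound 1 to compound 3 (0.31 log units; beyond the scatter) is the only one here that clears the scatter, while the step of an at least 1.6-fold higher number from compound 1 to compound 2 (0.21 log units; that floor lies within the scatter) does not. The step that the two limits leave unreadable from compound 2 to compound 3 is left unreadable by the two limits involved.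

Compound 4 `CNC(=O)c1cc(C(=O)NC2CC2)cn(CC2CCOCC2)c1=O` differs from compound 3 in one place: oxan-4-yl in place of 1H-benzimidazol-6-yl on a saturated chain carbon bound to an aromatic nitrogen. The closest guide is compound 2, whose oxan-3-yl group gives a reading that also sits at a limit (the limit of >= 131 ug/mL in this assay, at which 1 of the 3 values shown sits). Since a saturated oxane ring on that carbon already reached a limit there, compound 4 is expected to land near a limit as well, with the step of an at least 1.0-fold lower number from compound 3 to compound 4 (0.03 log units; that floor lies within the scatter) expected to stay within the scatter. The estimate for compound 4 is 150 ug/mL, in the range 70 ug/mL to 320 ug/mL.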

Compound 4, solubility: >= 165 ug/mL
Compound 4: a limit, no number (the forecaster's own chance of this, stated with the estimate: 60%); at least 1.1-fold (0.04 log units) between middle value and limit.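

In this assay, for the compounds shown here, compound 4 carries oxan-4-yl on the saturated chain carbon, and an at least 2.0-fold higher number from compound 1 to compound 4 (0.31 log units; beyond the scatter) makes it the one compound with a saturated oxane ring whose step from the 3-methoxyphenyl group clears the scatter. An aromatic group is therefore not needed on this carbon for a step of that kind, and neither is a hydrogen-bond donor, since oxan-4-yl has none. Compound 4 gives a limit, not a number: the limit of >= 165 ug/mL in this assay, at which 1 of the 4 values shown sits.

Going by these compounds, the steps to compound 4 from compound 2 and from compound 3 cannot be read, so the order of these three compounds stays unknown. Also open, on these data alone, is whether an amine or a carboxylic acid on this same carbon would give a number or another limit.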